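The source may hold more compounds than are shown below. What is called first, only, known or untested is meant among the compounds shown, and "the series" means these compounds.

In a functional assay on MCF7 cells (Homo sapiens) for cytotoxicity, read by CellTiter-Glo, with a stated time of 5 days (a lower number here means a stronger inhibitor, a higher number a weaker inhibitor), compound 2, whose structure is `CC/C(=C(/c1ccc(/C=C/C(=O)O)cc1)c1cc2cn[nH]c2cn1)c1ccccc1`, gives 442 nM. That is the higher of the two numbers recorded so far. The other measured compound, compound 1 with structure `O=C(O)/C=C/c1ccc(/C(=C(\c2ccccc2)C(F)F)c2ccc3[nH]ncc3c2)cc1`, gives 14 nM in this assay, a much lower number than compound 2, and the gap between the two lies well beyond the usual scatter.

Compound 3, with structure `CC/C(=C(/c1ccc(/C=C/C(=O)O)cc1)c1ccc2[nH]ncc2c1F)c1ccccc1`, has not yet been measured. It differs from compound 2 in a single place: a group of 10 heavy atoms (7 carbon, 2 nitrogen, 1 fluorine; one five-membered aromatic ring with 2 hetero atoms, one six-membered aromatic ring of carbon only) in place of a group of 9 heavy atoms (6 carbon, 3 nitrogen; one five-membered aromatic ring with 2 hetero atoms, one six-membered aromatic ring with 1 hetero atom), on a double-bonded chain carbon bound to an aromatic carbon and a double-bonded chain carbon. Going by the values given here, no direct step between measured compounds describes this exact swap, so the expectation rests on what the two measured values show. Among the compounds with values here, compound 1, the only measured compound that carries an indazolyl group at this position, gives 14 nM in this assay, so the step from compound 2 to compound 3 is expected to bring the number down by a clear margin, beyond the scatter, as an 11-fold lower number from compound 2 to compound 3 (1.04 log units; beyond the scatter). Compound 3 is therefore estimated at 40 nM in this assay, with a plausible range from 10 nM to 160 nM.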

Compound 3, half-maximal inhibitory concentration: 3 nM
Compound 3: middle estimate off by 13-fold (1.12 log units), on the high side, outside the stated range (below it).
By their numbers in this assay, from the lowest: compound 3; then compound 1; then compound 2.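

In this assay, the group on this double-bonded chain carbon proves to have a very strong influence: putting 4-fluoro-1H-indazol-5-yl there gives a 150-fold lower number from compound 2 to compound 3 (2.17 log units; beyond the scatter), a large change from a swap in one place with the rest of the molecule kept the same. Compound 1 and compound 2 differ in more than one place, so their gap could not be tied to this position alone, whereas this step can. No measurement shown here bears on why the step is so large.

The swap changes two things at once, as a six-membered ring with one hetero atom gives way to one of carbon only and a fluorine enters, so the compounds shown do not divide the step between these two changes. Also open, from the compounds shown here alone, is whether the same core would keep such a low number with an unsubstituted 1H-indazol-5-yl group, or with a chlorine or a methyl group in place of the fluorine.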